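Thiophene for Pyridine on the Hydrazide Carbonyl

This account rests on a few compounds, and the source may have more. Where it says the series, first, only, none or still open, it means among the compounds named here.

compound 1: `Nc1ccc(C(=O)NN=C(c2ccccn2)c2ccccn2)cc1`, 7640 nM
compound 2: `C/C(=N\NC(=O)c1ccncc1)c1cnccn1`, 5790 nM
compound 3: `Nc1ccc(C(=O)N/N=C/c2ccccn2)cc1`, > 80000 nM

All three were measured in an ADME assay on cells (Homo sapiens) for antiproliferative activity, read by MTT assay; a lower number here means a stronger inhibitor, a higher number a weaker inhibitor. Compound 2 gives 5790 nM, the lowest of the two numbers shown. Compound 1 gives 7640 nM, which lies within the scatter of the value of compound 2, so no order can be read between them. For compound 3 the assay reports only a limit, > 80000 nM; this is the limit of > 80000 nM in this assay, at which 1 of the 3 values shown sits. Compound 4 `C/C(=N\NC(=O)c1cccs1)c1cnccn1` has not yet been measured. It differs from compound 2 in one place: thiophen-2-yl in place of pyridin-4-yl on a carbonyl carbon. Among the measured compounds shown here, no measured pair isolates this change, so its direction cannot be read from the data; a step no larger than the scatter is expected in this assay. Compound 4 is thus expected to give 6000 nM, within a range from 2000 nM to 20000 nM. This estimate means an expected step of a 1.0-fold higher number from compound 2 to compound 4 (0.02 log units; within the scatter), which stays within the scatter.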

Compound 4, half-maximal inhibitory concentration in the Homo sapiens assay: 2130 nM
Compound 4: the middle estimate sits 2.8-fold (0.45 log units) above what was measured; the range from low to high includes it.
By their numbers in the Homo sapiens assay, from the lowest: compound 4; then compounds 2 and 1 (each within the scatter of the next). At a limit, above all of these: compound 3.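

Thiophen-2-yl in place of pyridin-4-yl on a carbonyl carbon gives the only readable step at this position in the Homo sapiens assay: a 2.7-fold lower number from compound 2 to compound 4 (0.43 log units; beyond the scatter). In a physicochemical assay for lipophilicity (on this read-out lower numbers stand for lower lipophilicity and higher numbers for higher lipophilicity), compound 2 gives 1.2 and compound 4 gives 2.6, so the same change also moves this second read-out, with a number 1.40 log units higher from compound 2 to compound 4 (beyond the scatter). This single pair cannot show whether the two steps are linked.

The compounds shown leave open whether a phenyl or furan-2-yl group in this place would give a similar step. They also leave open whether the step would hold on the core of compound 1.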